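This account rests on a few compounds, and the source may have more. Where it says the series, first, only, none or still open, it means among the compounds named here.

In a physicochemical assay for lipophilicity, read by HPLC, at pH 7.4 (a higher number here means a more lipophilic compound, a lower number a more polar compound), compound 1 `C[C@@H](Oc1cc2ccn(CCC(=O)O)c2cc1Cl)c1ccccn1` gives 2.17, compound 2 `C[C@@H](Oc1cc2oc(=O)n(CCC(=O)O)c2cc1Cl)c1ccc(F)cn1` gives 1.98 and compound 3 `CCc1cc2oc(=O)n(CCC(=O)O)c2cc1Cl` gives 1.94. These numbers lie within the usual scatter of one another, so compound 3 cannot be told apart from the other two. Compound 4 `CC(C)Cc1cc2oc(=O)n(CCC(=O)O)c2cc1Cl` has isopropyl in place of methyl on a saturated chain carbon bound to an aromatic carbon. The same difference reads ethyl to isobutyl. Among the measured compounds shown here, no measured pair shows this change, so the expectation rests on the structures alone: only carbon enters, and a moderate rise beyond the scatter is expected in this assay. The estimated step is a number 0.66 log units higher from compound 3 to compound 4 (beyond the scatter). For compound 4 the estimated value is 2.6, with an expected range of 2.2 to 3.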

Compound 4, distribution coefficient: 3.03
Estimate against measurement, compound 4: 0.43 log units below; the measured number lies above the stated range.
By their numbers in this assay, from the lowest: compounds 3, 2 and 1 (each within the scatter of the next); then compound 4.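

In this assay, isopropyl in place of methyl on a saturated chain carbon bound to an aromatic carbon gives a number 1.09 log units higher from compound 3 to compound 4 (beyond the scatter) and is a large step. Among the compounds shown here, it is the first pair here that differs in one place, and it shows that this position responds to a change in which only carbon enters, ethyl to isobutyl. Nothing at hand accounts for the size of this step. Still open, from the compounds shown here alone, is how a longer straight chain, a cyclopropyl ring or a chain ending in a hydroxyl or an amine would read at this position. A single step also leaves open whether this change would give a similar step on the core of compound 1.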